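Benzoyl in place of phenylsulfonyl on the aromatic oxygen

This account rests on a few compounds, and the source may have more. Where it says the series, first, only, none or still open, it means among the compounds named here.

Among the measured compounds shown here, compound 3 `O=C(c1ccc(Cl)c(C(F)(F)F)c1)N1CCC(n2cncc2-c2ccc(OS(=O)(=O)c3ccccc3)cc2)CC1` is the only member of the series with a measured number in an assay on HEK293 cells for antagonist activity at P2X purinoceptor 7 (Homo sapiens), read by fluorescence, with a stated time of 2 h (on this read-out lower numbers stand for stronger inhibition and higher numbers for weaker inhibition), where compound 3 gives 702 nM. Compound 1 `O=C(Oc1ccc(-c2cncn2C2CCN(C(=O)c3ccc(Cl)c(C(F)(F)F)c3)CC2)cc1)c1cccc2cnccc12` reaches only the limit of the assay in this assay, reported as > 10000 nM. Compound 2 `CC(=O)Oc1ccc(-c2cncn2C2CCN(C(=O)c3ccc(Cl)c(C(F)(F)F)c3)CC2)cc1` likewise sits at the limit, with > 10000 nM. The step that the two limits leave unreadable from compound 1 to compound 2 therefore cannot be sized. The steps of an at least 14-fold lower number from compound 1 to compound 3 (1.15 log units; beyond the scatter) and an at least 14-fold lower number from compound 2 to compound 3 (1.15 log units; beyond the scatter) both run toward compound 3 and are large, which sets the phenylsulfonyl compound apart from the two carbonyl-bearing compounds that share (the limit of > 10000 nM in this assay, at which 2 of the 3 values shown sit).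

Compound 4 `O=C(Oc1ccc(-c2cncn2C2CCN(C(=O)c3ccc(Cl)c(C(F)(F)F)c3)CC2)cc1)c1ccccc1` is not yet measured. Its change from compound 3 reads (benzoyl in place of phenylsulfonyl on an oxygen on an aromatic ring). For the measured compounds named here, the change returns the group on the aromatic oxygen to a carbonyl, as carried by compound 1 and compound 2, so the steps that bear on it are the two large ones, an at least 14-fold lower number from compound 1 to compound 3 (1.15 log units; beyond the scatter) and an at least 14-fold lower number from compound 2 to compound 3 (1.15 log units; beyond the scatter), now read in reverse. A large upward step in this assay is expected, a 7.1-fold higher number from compound 3 to compound 4 (0.85 log units; beyond the scatter), with a fair chance that only a limit is reported again. Compound 4 is estimated at 5000 nM, within 1500 nM to 20000 nM.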

Compound 4, half-maximal inhibitory concentration: > 10000 nM
Compound 4: no number, only a limit; the forecaster's own chance of this, stated with the estimate: 45%; middle value at least 2.0-fold (0.30 log units) from the limit.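

The step of an at least 14-fold higher number from compound 3 to compound 4 (1.15 log units; beyond the scatter) in this assay keeps a six-membered aromatic ring of carbon only on both sides of the exchange. The gap therefore goes with the link on the oxygen on the aromatic ring, sulfonyl against carbonyl, a reading that the steps to compound 3 from compound 1 and compound 2 could not give, since the ring changed in those steps as well. Methyl, phenyl and isoquinolin-5-yl on the carbonyl carbon all end at one limit, so the steps among compound 1, compound 2 and compound 4 cannot be read and no order among these groups follows: the limit of > 10000 nM in this assay, at which 3 of the 4 values shown sit.

Among the compounds shown here, compound 3 remains the only compound with phenylsulfonyl and the only one with a measured number, so it is unclear whether a number would survive with methyl or a substituted phenyl on the sulfur. From the compounds shown here alone, it is equally open whether the oxygen on the aromatic ring matters, which a sulfonamide, with an amine nitrogen in its place, would test.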